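Pendant ring swap in the biphenyl propanamide

The source may report more compounds than this note shows. Statements on the series, on what has been measured and on what is new or still open speak of the compounds shown alone.

Working notes on three pyrrolidine amides with aryl-terminated chains. Compound 1 `Cc1cccc(CCCCCCC(=O)N2CCCC2)c1` gives 8300 nM in an assay on HEK293 cells for inhibition of N-acylethanolamine-hydrolyzing acid amidase (Rattus norvegicus), read by LC-MS, with a stated time of 30 min; a lower number here means a stronger inhibitor, a higher number a weaker inhibitor. Compound 2 `O=C(CCCCCCc1cccc(Cl)c1)N1CCCC1` gives 3700 nM in this assay. Compound 3 `Cc1ccc(-c2ccc(CCC(=O)N3CCCC3)cc2)cc1`, the shorter chain with a biaryl end, gives 33200 nM in this assay and stands highest of the three numbers, with compound 1 nearest and compound 2 furthest.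

Going by the values given here, the one step so far between two measured compounds is a 2.2-fold lower number from compound 1 to compound 2 (0.35 log units; beyond the scatter), a chloro in place of methyl on an aromatic carbon, measured on the longer chain.

Compound 4 `O=C(CCc1ccc(-c2cccc(Cl)c2)cc1)N1CCCC1` differs from compound 3 by 3-chlorophenyl in place of 4-methylphenyl on an aromatic carbon. This is the same chloro-for-methyl exchange as the step from compound 1 to compound 2, but on a different core and with the substituent moving to a different carbon of the pendant ring, so that step bears on it only in part. A modest step toward a lower number in this assay is expected, of about the size seen from compound 1 to compound 2, with wide uncertainty because the pendant ring itself is rearranged.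

Compound 4 is therefore estimated at 15000 nM, within 6000 nM to 40000 nM, which corresponds to an expected step of a 2.2-fold lower number from compound 3 to compound 4 (0.35 log units; beyond the scatter).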

Compound 4, half-maximal inhibitory concentration: 25400 nM
For compound 4 the middle estimate is 1.7-fold (0.23 log units) below the measured one, and the stated range covers the measured number.
By their numbers in this assay, from the lowest: compound 2; then compound 1; then compounds 4 and 3 (each within the scatter of the next).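

On the biaryl end, in this assay, 3-chlorophenyl in place of 4-methylphenyl, on an aromatic carbon para to a group of 9 heavy atoms, gives a 1.3-fold lower number from compound 3 to compound 4 (0.12 log units; within the scatter) and so leaves compound 3 and compound 4 inseparable in this assay. The chloro-for-methyl exchange on the longer chain, a 2.2-fold lower number from compound 1 to compound 2 (0.35 log units; beyond the scatter), lies beyond the scatter, so a step of that kind on one core does not carry over to this exchange on the other, where the substituent also sits on a different carbon of the pendant ring. Nothing available gives a reason for the difference between the two steps.

Because this exchange alters both the substituent and its carbon, the pair cannot tell whether either alone has any effect on this core, and 4-chlorophenyl or 3-methylphenyl at the same place would separate the two. Also open, from the compounds shown here alone, is whether a longer chain between the biaryl end and the pyrrolidine amide would bring out the chloro-for-methyl step seen on compound 1 and compound 2.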